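The source may hold more compounds than are shown below. What is called first, only, known or untested is meant among the compounds shown, and "the series" means these compounds.

Measured so far:
- compound 1, `CCOC(=O)/C(CCCC(=O)O)=N\Nc1ccc(OC)cc1`, 43000 nM
- compound 2, `CCOC(=O)/C(CCCC(=O)O)=N\Nc1ccc([N+](=O)[O-])cc1`, 179000 nM
- compound 3, `O=C(O)CCc1c(C(=O)O)[nH]c2ccc(Cl)cc12`, 293000 nM

All three were tested in an assay on isolated protein for inhibition of kynurenine--oxoglutarate transaminase 1 (Homo sapiens), read by HPLC, with a stated time of 20 min; on this read-out lower numbers stand for stronger inhibition and higher numbers for weaker inhibition. Compound 2 stands second highest of the three numbers: its nearest neighbour is compound 3, and the gap between these two values is within the scatter, so nothing separates them; compound 1 is further away, with a lower number.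

Compound 4, `CCOC(=O)/C(CCCC(=O)O)=N\Nc1ccc(I)cc1`, is not yet measured. It differs from compound 2 in one place: iodo in place of nitro on an aromatic carbon. For the measured compounds named here, the only measured step that bears on this is the one from compound 1 to compound 2, in which the nitro group replaced a methoxy group at the same place and gave a 4.2-fold higher number from compound 1 to compound 2 (0.62 log units; beyond the scatter). That step shows that swapping the group para to a large group can move the number modestly in this assay. Going by the values given here, no measured step shows iodo at this place, so the direction is open; a modest move in either direction is plausible. Compound 4 is therefore expected to land near or somewhat below compound 2, estimated at 60000 nM, in the range 15000 nM to 200000 nM, meaning a 3.0-fold lower number from compound 2 to compound 4 (0.47 log units; beyond the scatter).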

Compound 4, half-maximal inhibitory concentration: 34000 nM
Compound 4: the middle estimate sits 1.8-fold (0.25 log units) above what was measured; the range from low to high includes it.
By their numbers in this assay, from the lowest: compounds 4 and 1 (each within the scatter of the next); then compounds 2 and 3 (each within the scatter of the next).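

In this assay, iodo in place of nitro on this aromatic carbon gives a 5.3-fold lower number from compound 2 to compound 4 (0.72 log units; beyond the scatter) and so shows that the number at this place can fall from the nitro value, a move that the earlier step, which ended on nitro, showed only in the upward direction. Iodo in place of methoxy gives a 1.3-fold lower number from compound 1 to compound 4 (0.10 log units; within the scatter) and lies within the scatter, so these two groups cannot be told apart here even though they are very different substituents. Among the three groups tried at this place, nitro alone stands apart, with the higher number, while iodo and methoxy sit together.

On these data alone, whether an amine, a nitrile or a smaller halogen such as fluoro would sit with iodo and methoxy or with nitro remains open. Nothing available here explains why nitro differs from the other two groups.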